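The source may report more compounds than this note shows. Statements on the series, on what has been measured and on what is new or still open speak of the compounds shown alone.

Measured compounds:

Compound 1, `COc1ccc(/C=C/C2CC=CC(=O)N2)c(OC)c1`: > 964 uM
Compound 2, `COc1ccc(/C=C/C2CC=CC(=O)N2)cc1OC`: > 964 uM

Compound 1, `COc1ccc(/C=C/C2CC=CC(=O)N2)c(OC)c1`, and compound 2, `COc1ccc(/C=C/C2CC=CC(=O)N2)cc1OC`, share one core and differ only in how their two methoxy groups are set around the aromatic ring. In a functional assay on MCF7 cells (Homo sapiens) for inhibition, read by sulforhodamine B assay, with a stated time of 48 h (on this read-out higher numbers stand for weaker inhibition of growth and lower numbers for stronger inhibition of growth), compound 1 gives > 964 uM, which is a limit of the assay and not a number. In the same assay compound 2 gives > 964 uM, again a limit of the assay rather than a number. Going by the values given here, compound 2 therefore stands at the limit of > 964 uM in this assay, at which 2 of the 2 values shown sit, and nothing among the measured values separates it from compound 1.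

Compound 3, `COc1cc(OC)c(OC)cc1/C=C/C1CC=CC(=O)N1`, is the compound not yet measured. It differs from compound 2 by methoxy in place of hydrogen on an aromatic carbon. Among the compounds with values here, no step between measured compounds is available to calibrate this change, so the expectation rests on the two limits alone. The step from compound 2 to compound 3 is expected to be none beyond the scatter, with a step that the limit leaves unreadable from compound 2 to compound 3. For compound 3 in this assay the estimate is 1000 uM, with a range from 300 uM to 3000 uM, and most likely the assay will again report only a limit.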

Compound 3, concentration for growth inhibition (reported as GI): > 864 uM
Compound 3: a limit, no number; the forecaster's own chance of this, stated with the estimate: 80%; the middle value does not contradict the limit.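

In this assay compound 3 gives > 864 uM, again a limit of the assay and not a number. The steps from compound 1 and from compound 2 to compound 3 therefore cannot be read. The compounds shown leave open whether methoxy in place of hydrogen on an aromatic carbon changes inhibition of growth at all, and how compound 1, compound 2 and compound 3 rank in this assay.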